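Amide to Urea Swap: Expected Growth Inhibition

The source may report more compounds than this note shows. Statements on the series, on what has been measured and on what is new or still open speak of the compounds shown alone.

Compound 1, `COc1cc(-c2nn(-c3cccc(NC(=O)c4cccc(C(F)(F)F)c4)c3)cc2-c2ccncc2)ccc1Cl`, gives > 50000 nM in a functional assay on SK-MEL-2 cells (Homo sapiens) for inhibition, read by sulforhodamine B assay, with a stated time of 48 h; on this read-out lower numbers stand for stronger inhibition of growth and higher numbers for weaker inhibition of growth; this is a limit of the assay, not a number.
Compound 2, `COc1cc(-c2nn(-c3cccc(NC(=O)c4ccc(Cl)c(C(F)(F)F)c4)c3)cc2-c2ccncc2)ccc1Cl`, gives 19700 nM.
Compound 3, `COc1cc(-c2nn(-c3cccc(NC(=O)Nc4ccc(Cl)c(C(F)(F)F)c4)c3)cc2-c2ccncc2)ccc1Cl`, is not yet measured.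

Compound 2 holds the only real number shown, since compound 1 sits at the limit of > 50000 nM in this assay, at which 1 of the 2 values shown sits. Among the compounds with values here, the one measured step, an at least 2.5-fold lower number from compound 1 to compound 2 (0.40 log units; beyond the scatter), concerns an added chloro elsewhere, whereas compound 3 differs from compound 2 by (4-chloro-3-(trifluoromethyl)phenyl)amino in place of 4-chloro-3-(trifluoromethyl)phenyl on a carbonyl carbon. Within the data shown here, no measured step bears on this change, so no step beyond the scatter is expected: a 1.3-fold lower number from compound 2 to compound 3 (0.12 log units; within the scatter). Compound 3 is therefore estimated at 15000 nM, between 4000 nM and 50000 nM.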

Compound 3, concentration for total growth inhibition: 2580 nM
The estimate for compound 3 lay 5.8-fold (0.76 log units) above the measured number; measured number below the stated range.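

In this assay, placing an amino nitrogen on the carbonyl carbon, which turns the amide into a urea, brings a clear gain: a 7.6-fold lower number from compound 2 to compound 3 (0.88 log units; beyond the scatter). Together with the chloro, the change gives an at least 19-fold lower number from compound 1 to compound 3 (1.28 log units; beyond the scatter). That second step is only a bound, since compound 1 stands at a limit: the limit of > 50000 nM in this assay, at which 1 of the 3 values shown sits.

The compounds shown do not tell why the urea gives the lower number. They also leave open how a thiourea, or a urea carrying a methyl group on that nitrogen, would behave in this place.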